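The source may hold more compounds than are shown below. What is called first, only, known or untested is meant among the compounds shown, and "the series" means these compounds.

In an assay on HEK293 cells for inhibition of Indoleamine 2,3-dioxygenase 1 (Homo sapiens), tested at 10 uM (on this read-out higher numbers stand for more inhibition at the one concentration tested (going by the name of the read-out) and lower numbers for less inhibition), compound 2 `CC(C)C(=O)N1CCc2cc(CNC(=O)c3cccs3)ccc21` gives 100%, the highest of the two numbers at hand. Among the measured compounds shown here, compound 1 `CC(C)C(=O)N1CCc2cc(CNC(=O)c3ccc(F)cc3)ccc21` gives 88% in this assay, and the only measured step, a number 12 percentage points higher from compound 1 to compound 2 (beyond the scatter), concerns the aryl group on the carbonyl carbon. Compound 3 `CCC(=O)N1CCc2cc(CNC(=O)c3cccs3)ccc21` has not been measured in this assay. It differs from compound 2 by hydrogen in place of methyl on a saturated chain carbon bound to a carbonyl carbon and a saturated chain carbon. For the measured compounds named here, no measured step touches this part of the molecule: the single step between compound 1 and compound 2 alters a different position and therefore gives no guide to the size or direction of the present change. With nothing to go on, compound 3 is expected to stay close to compound 2. The step of a number 7 percentage points lower from compound 2 to compound 3 (within the scatter) is accordingly expected to fall within the scatter. Compound 3 is estimated at 93%, with a range from 75% to 100%.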

Compound 3, a percentage reported as inhibition, at one concentration (the size of the read-out at that concentration, not a potency): 89%
Compound 3: the middle estimate sits 4 percentage points above what was measured; measured number inside the range.
By their numbers in this assay, from the lowest: compounds 1 and 3 (each within the scatter of the next); then compound 2.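

Cutting isopropyl to ethyl gives a number 11 percentage points lower from compound 2 to compound 3 (beyond the scatter) in this assay, so this position, which the earlier compounds left unchanged, does respond to the loss of a single methyl. The step is modest, as is a number 12 percentage points higher from compound 1 to compound 2 (beyond the scatter) at the group on the other carbonyl carbon, so both places on the molecule now have a measured effect in this series. Nothing measured here bears on why the number falls at this position.

The compounds shown leave open how a cyclopropyl, a tert-butyl, a longer chain or an amine would read at this place, and whether going on to methyl would extend the same trend. They also leave open whether isopropyl to ethyl gives a step of similar size when 4-fluorophenyl stands in place of thiophen-2-yl.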